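This account rests on a few compounds, and the source may have more. Where it says the series, first, only, none or still open, it means among the compounds named here.

Of the compounds shown here, three sharing one core have been measured. Compound 1 `CO[C@H]1C[C@H](O[Si](C)(C)C(C)(C)C)O[C@@H](C)/C1=C/CO` carries a hydroxymethyl group on the double-bonded chain carbon, and in a functional assay on the whole organism for inhibition, with Artemia salina as the target (a lower number here means a stronger inhibitor of growth, a higher number a weaker inhibitor of growth), compound 1 gives 0.01 ug/mL. Compound 2 `C=CCOC(=O)/C=C1/[C@H](C)O[C@@H](O[Si](C)(C)C(C)(C)C)C[C@@H]1OC` bears an allyloxycarbonyl group at that carbon; in this assay compound 2 gives 0.002 ug/mL. Compound 3 `CCOC(=O)/C=C1/[C@H](C)O[C@@H](O[Si](C)(C)C(C)(C)C)C[C@@H]1OC` bears an ethoxycarbonyl group there, and in this assay compound 3 gives 0.01 ug/mL. Compound 3 thus stands level with compound 1, the two together giving the highest of the three numbers, while compound 2 lies furthest from it: a number 2.3 two-fold dilutions higher from compound 2 to compound 3 (beyond the scatter).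

Compound 4 `CO[C@H]1C[C@H](O[Si](C)(C)C(C)(C)C)O[C@@H](C)/C1=C/C(=O)N1CCCCC1` differs from compound 3 in one place: piperidin-1-yl in place of ethoxy on a carbonyl carbon. Of the measured steps, no change at the digits printed from compound 1 to compound 3 (within the scatter) and a number 2.3 two-fold dilutions lower from compound 1 to compound 2 (beyond the scatter) show what exchanges at the double-bonded chain carbon did, and a number 2.3 two-fold dilutions higher from compound 2 to compound 3 (beyond the scatter) shows what altering the group bound to the ester oxygen did. None of them exchanges an ester for an amide, so their bearing on compound 4 is indirect. The whole span covered by the three compounds is modest, and for compound 4 no step beyond the scatter is expected: no change at the digits printed from compound 3 to compound 4 (within the scatter). For compound 4 in this assay the estimate is 0.01 ug/mL, with a range from 0.003 ug/mL to 0.04 ug/mL.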

Compound 4, minimum inhibitory concentration: 0.002 ug/mL
Compound 4: the middle estimate sits 2.3 two-fold dilutions above what was measured; measured number below the stated range.
By their numbers in this assay, from the lowest: compounds 2 and 4 (each within the scatter of the next); then compounds 1 and 3 (each within the scatter of the next).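

Piperidin-1-yl in place of ethoxy on the carbonyl carbon brings the first amide into the series, and in this assay this exchange gives a number 2.3 two-fold dilutions lower from compound 3 to compound 4 (beyond the scatter) as its result, so the carbonyl carbon tolerates nitrogen in place of the ester oxygen without any loss in this read-out. Set against the allyl ester, the amide shows no change at the digits printed from compound 2 to compound 4 (within the scatter) as its step, and set against the alcohol it shows a number 2.3 two-fold dilutions lower from compound 1 to compound 4 (beyond the scatter) as its step, which means that ethoxycarbonyl, not the carbonyl group as such, is the member that sits level with hydroxymethyl among these compounds. Nothing among the data shown explains why piperidin-1-yl and allyloxy end up level or why ethoxy differs from both.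

The compounds shown leave open whether the piperidine ring itself matters or any amide at this carbon would do, a question that a simple dimethylamino group or a morpholin-4-yl ring in the same place would address. They also leave open how a free carboxylic acid at this carbon would read, and whether any of these steps would hold on a core carrying a free hydroxyl in place of the silyl ether.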